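Swapping trifluoromethyl for chloro on the urea aryl ring

The source may report more compounds than this note shows. Statements on the series, on what has been measured and on what is new or still open speak of the compounds shown alone.

Compound 2 `COc1cc2cc(Oc3ccc(NC(=O)Nc4ccc(Cl)c(C(F)(F)F)c4)cc3)c(C)nc2cc1OC` gives 1200 nM in a functional assay on HT-29 cells (Homo sapiens) for inhibition, read by sulforhodamine B assay, with a stated time of 48 h (a lower number here means a stronger inhibitor of growth, a higher number a weaker inhibitor of growth), the lower of the two numbers shown, though the gap to compound 1 stays within the scatter. For the measured compounds named here, compound 1 `COc1cc2cc(Oc3ccc(NC(=O)Nc4cccc(C(F)(F)F)c4)cc3)c(C)nc2cc1OC` gives 2050 nM, and the one measured step, a 1.7-fold lower number from compound 1 to compound 2 (0.23 log units; within the scatter), is small. Compound 3 `COc1cc2cc(Oc3ccc(NC(=O)Nc4ccc(Cl)c(Cl)c4)cc3)c(C)nc2cc1OC` differs from compound 2 by chloro in place of trifluoromethyl on an aromatic carbon. Going by the values given here, no measured step touches that position, so only the modest size of the neighbouring change offers guidance. Compound 3 is therefore expected to stay close, with an estimated step of a 1.3-fold higher number from compound 2 to compound 3 (0.10 log units; within the scatter) and a value of 1500 nM, ranging from 600 nM to 4000 nM.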

Compound 3, concentration for 50% growth inhibition: 2340 nM
Compound 3: middle estimate off by 1.6-fold (0.19 log units), on the low side, and the stated range covers the measured number.
By their numbers in this assay, from the lowest: compounds 2, 1 and 3 (each within the scatter of the next).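

In this assay, for the compounds shown here, the first measured change at this position, with chloro replacing trifluoromethyl, gives a 2.0-fold higher number from compound 2 to compound 3 (0.29 log units; within the scatter) and so cannot be told from repeat measurement, although one heavy atom stands in for four. The step that also takes in the second ring chloro gives a 1.1-fold higher number from compound 1 to compound 3 (0.06 log units; within the scatter) and likewise shows no separation. Nothing available explains these numbers. Going by these compounds, whether a nitrile, a methoxy group or an amine at this position would also stay within the scatter remains open. So does whether any group on this ring can move the number beyond it.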